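This account rests on a few compounds, and the source may have more. Where it says the series, first, only, none or still open, it means among the compounds named here.

In a functional assay on DU-145 cells (Homo sapiens) for inhibition, read by trypan blue exclusion, with a stated time of 96 h (a higher number here means a weaker inhibitor of growth, a lower number a stronger inhibitor of growth), compound 3 (`O=C(/C(=C\c1ccc([N+](=O)[O-])c(O)c1)SCc1ccc(Br)cc1)c1ccc(Br)cc1`) gives 10000 nM, level with compound 2 (`O=C(O)c1ccc(C(=O)/C(=C\c2ccc([N+](=O)[O-])c(O)c2)SCc2ccc(Br)cc2)cc1`) at 10000 nM, and together they hold the highest number of the three measured. Compound 1 (`O=C(/C(=C\c1ccc([N+](=O)[O-])c(O)c1)SCc1ccc(Br)cc1)c1ccc([N+](=O)[O-])cc1`) gives 1000 nM. Compound 4 (`O=C(/C(=C\c1ccc([N+](=O)[O-])c(O)c1)SCc1ccc(Br)cc1)c1c(F)c(F)c(F)c(F)c1F`) carries 2,3,4,5,6-pentafluorophenyl in place of 4-bromophenyl on a carbonyl carbon. Within the data shown here, no measured compound carries this group, so the evidence is indirect. Both a 10-fold higher number from compound 1 to compound 3 (1.00 log units; beyond the scatter) and a 10-fold higher number from compound 1 to compound 2 (1.00 log units; beyond the scatter) are modest and lie beyond the scatter, whereas no change at the digits printed from compound 2 to compound 3 (within the scatter) lies within it. A small move toward the lower number is therefore expected, smaller than those two modest steps. The estimated change is a 2.0-fold lower number from compound 3 to compound 4 (0.30 log units; within the scatter). For compound 4 the expected value is 5000 nM, with an estimated range of 1500 nM to 15000 nM.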

Compound 4, concentration for 50% growth inhibition: 10000 nM
Compound 4: the middle estimate sits 2.0-fold (0.30 log units) below what was measured, and the stated range covers the measured number.
By their numbers in this assay, from the lowest: compound 1; then compounds 2, 3 and 4 (each within the scatter of the next).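

At the carbonyl carbon, in this assay, 2,3,4,5,6-pentafluorophenyl stands level with 4-bromophenyl (no change at the digits printed from compound 3 to compound 4 (within the scatter)) and with 4-carboxyphenyl (no change at the digits printed from compound 2 to compound 4 (within the scatter)). Only 4-nitrophenyl stands apart (a 10-fold higher number from compound 1 to compound 4 (1.00 log units; beyond the scatter)), so three different groups at this position share one number and a single group gives the lower one. Nothing measured here accounts for this. The compounds shown leave open whether the lower number belongs to 4-nitrophenyl alone, and how 4-cyanophenyl or 4-aminophenyl would read at this carbon.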